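A few compounds are considered here, and "the series" means these few. Any claim that something is new, unique, unknown or untested is made for them only; others in the source may bear on it.

Compound 1 `CNc1cc(Oc2ccc(NC(=O)Nc3ccccc3)cc2)ncn1`, compound 2 `CNc1cc(Oc2ccc(NC(=O)Nc3cccc(C(F)(F)F)c3)cc2)ncn1` and compound 3 `CNc1cc(Oc2ccc(NC(=O)Nc3cccc(C(C)(C)C)c3)cc2)ncn1` share one core and differ only on the outer aromatic ring. In an assay on isolated protein for inhibition of serine/threonine-protein kinase TNNI3K (Homo sapiens) (on this read-out higher numbers stand for weaker inhibition and lower numbers for stronger inhibition), compound 1 gives 6300 nM, compound 2 gives 40 nM and compound 3 gives 40 nM. Compound 2 thus sits level with compound 3, together the lowest numbers of the three, after a 160-fold lower number from compound 1 to compound 2 (2.20 log units; beyond the scatter); a 160-fold lower number from compound 1 to compound 3 (2.20 log units; beyond the scatter) and no change at the digits printed from compound 2 to compound 3 (within the scatter) complete the picture. Compound 4 `CC(C)CNc1cc(Oc2ccc(NC(=O)Nc3cccc(C(F)(F)F)c3)cc2)ncn1` alters a different place: isopropyl in place of hydrogen on a saturated chain carbon bound to a nitrogen on an aromatic ring. Going by the values given here, none of the measured steps touches this nitrogen; all of them concern the outer ring, so they give no direct guide, and the shared core is left unchanged. The expected step is therefore a 1.5-fold higher number from compound 2 to compound 4 (0.18 log units; within the scatter), within the scatter. Compound 4 is expected to give about 60 nM in this assay, in a range from 15 nM to 250 nM.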

Compound 4, half-maximal inhibitory concentration: 50 nM
Compound 4: the middle estimate sits 1.2-fold (0.08 log units) above what was measured; measured number inside the range.
By their numbers in this assay, from the lowest: compounds 2, 3 and 4 (each within the scatter of the next); then compound 1.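

In this assay the change from methylamino to isobutylamino gives a 1.3-fold higher number from compound 2 to compound 4 (0.10 log units; within the scatter) and so leaves the number within the scatter. Going by these compounds alone, this is the first measured change at this nitrogen, and it shows that an added isopropyl of 3 carbon atoms can sit here without a step beyond the scatter, whereas the large steps so far came from the outer ring. No measurement available here explains this result.

Going by these compounds, whether a longer chain, a cyclohexyl group or a carboxylic acid on this nitrogen would also leave the number unchanged stays open. So does whether isobutylamino would give the same result on compound 3, which carries tert-butyl in place of trifluoromethyl.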